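The source may report more compounds than this note shows. Statements on the series, on what has been measured and on what is new or still open speak of the compounds shown alone.

Compound 1 `CCN(CC)c1nc(Nc2ccc(C(=O)O)cc2)nc(OC(C(F)(F)F)C(F)(F)F)n1` — 900 nM
Compound 2 `CCN(CC)c1nc(Nc2ccc(F)cc2)nc(OC(C(F)(F)F)C(F)(F)F)n1` — 700 nM
Compound 3 `CCN(CC)c1nc(Nc2ccc3cn[nH]c3c2)nc(OC(C(F)(F)F)C(F)(F)F)n1` — 900 nM

In an assay on cells for activation of Cystic fibrosis transmembrane conductance regulator (Homo sapiens), read by fluorescence, with stated times of 10 min and 12 s (a higher number here means that more compound is needed for the effect, a lower number that less compound is needed), compound 3 sits level with compound 1 and close to compound 2; the steps of no change at the digits printed from compound 1 to compound 3 (within the scatter) and a 1.3-fold higher number from compound 2 to compound 3 (0.11 log units; within the scatter) both fall within the scatter, so the three groups on that nitrogen give numbers that cannot be told apart. Compound 4 `CCN(CC)c1nc(Nc2ccc3[nH]ncc3c2)nc(OC(C(F)(F)F)C(F)(F)F)n1` carries a change of a different kind: 1H-indazol-5-yl in place of 1H-indazol-6-yl on a nitrogen on an aromatic ring. For the measured compounds named here, no measured step moves an attachment point within the same group, so the only guide is that swapping the whole group, as in no change at the digits printed from compound 1 to compound 3 (within the scatter) and a 1.3-fold higher number from compound 2 to compound 3 (0.11 log units; within the scatter), left the number unchanged. The expectation is therefore no step beyond the scatter, no change at the digits printed from compound 3 to compound 4 (within the scatter). Compound 4 is estimated at 900 nM, with a range from 400 nM to 2000 nM.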

Compound 4, half-maximal effective concentration: 2800 nM
Compound 4: middle estimate off by 3.1-fold (0.49 log units), on the low side; measured number outside the range, above it.
By their numbers in this assay, from the lowest: compounds 2, 1 and 3 (each within the scatter of the next); then compound 4.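

In this assay, moving only the attachment point of the indazole on the nitrogen, with the same atoms, gives a 3.1-fold higher number from compound 3 to compound 4 (0.49 log units; beyond the scatter), whereas the groups in compound 1, compound 2 and compound 3 could not be told apart. This separates the 1H-indazol-5-yl group from the other two groups as well, with a 4.0-fold higher number from compound 2 to compound 4 (0.60 log units; beyond the scatter) and a 3.1-fold higher number from compound 1 to compound 4 (0.49 log units; beyond the scatter). Nothing available explains this difference.

Still open, as far as these compounds go, is how a 1H-benzimidazol-5-yl or 4-aminophenyl group on that nitrogen would compare. Whether the gap between the two indazoles persists with other groups on the shared core is also unknown.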